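Urea-to-amide exchange on the pyrazole biaryl series

A few compounds are considered here, and "the series" means these few. Any claim that something is new, unique, unknown or untested is made for them only; others in the source may bear on it.

Compound 1 `COc1cc(-c2nn(-c3cccc(NC(=O)Nc4ccc(Cl)c(Cl)c4)c3)cc2-c2ccncc2)ccc1Cl` is the reference point of the series. In a functional assay on OVCAR-8 cells (Homo sapiens) for inhibition, read by sulforhodamine B assay, with a stated time of 48 h (a higher number here means a weaker inhibitor of growth, a lower number a stronger inhibitor of growth), compound 1 gives 931 nM. Going by the values given here, the only other measured compound, compound 2 `O=C(Nc1cccc(-n2cc(-c3ccncc3)c(-c3ccc(Cl)c(O)c3)n2)c1)Nc1ccc(Cl)c(Cl)c1`, gives 1210 nM in this assay, and the step of a 1.3-fold higher number from compound 1 to compound 2 (0.11 log units; within the scatter) leaves the two within the scatter of each other; that step concerns only the group on the oxygen and says nothing about the urea end of the molecule.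

Compound 3 `COc1cc(-c2nn(-c3cccc(NC(=O)c4ccc(Cl)c(C(F)(F)F)c4)c3)cc2-c2ccncc2)ccc1Cl` differs from compound 1 at that urea end: 4-chloro-3-(trifluoromethyl)phenyl in place of (3,4-dichlorophenyl)amino on a carbonyl carbon. Among the compounds with values here, no measured step touches this part of the structure, so there is no precedent here for the size or direction of the change. The working expectation for compound 3 is therefore a number near that of compound 1, with a wide range to allow for an unprecedented change, giving an expected step of a 1.2-fold higher number from compound 1 to compound 3 (0.07 log units; within the scatter). Compound 3 is estimated at 1100 nM, between 250 nM and 5000 nM.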

Compound 3, concentration for 50% growth inhibition: 3350 nM
Beside the measured number, compound 3's estimate is 3.0-fold (0.48 log units) below it; the measured number falls inside the stated range.
By their numbers in this assay, from the lowest: compounds 1 and 2 (each within the scatter of the next); then compound 3.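

Going by these compounds alone, this is the first change at the urea end of the series, and in this assay it moves the number beyond the scatter: a 3.6-fold higher number from compound 1 to compound 3 (0.56 log units; beyond the scatter). The step is modest, but the urea end responds to substitution in a way the change on the oxygen between compound 1 and compound 2 could not show. The exchange alters two features together, replacing the amino link, with its hydrogen-bond donor, and changing the ring substituents from two chlorines to chlorine plus trifluoromethyl; no measurement available here explains the higher number.

The compounds shown leave open which of those two features accounts for the step, a question that 3,4-dichlorophenyl directly on the carbonyl carbon or (4-chloro-3-(trifluoromethyl)phenyl)amino in the same place would address. Also open, as far as these compounds go, is how a methylene link between the carbonyl carbon and the ring would read in this assay.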